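This account rests on a few compounds, and the source may have more. Where it says the series, first, only, none or still open, it means among the compounds named here.

Measured so far:
- compound 1, `O=C(Nc1ccc(-c2noc(-c3cccc(NS(=O)(=O)c4ccccc4)c3)n2)c(Cl)c1)c1cccnc1`: > 10000 nM
- compound 2, `Cc1ccc(NC(=O)Nc2cccc(-c3nc(-c4ccc(NC(=O)c5cccnc5)cc4Cl)no3)c2)cc1`: 3500 nM

In a functional assay on MDA-MB-231 cells (Homo sapiens) for antiproliferative activity, read by MTT assay, with a stated time of 72 h (on this read-out higher numbers stand for weaker inhibition and lower numbers for stronger inhibition), compound 1 sits at the limit of > 10000 nM in this assay, at which 1 of the 2 values shown sits, a limit of the assay rather than a number. Among the compounds with values here, compound 2 gives 3500 nM, the only number among the values shown. Within the data shown here, the one measured step is an at least 2.8-fold lower number from compound 1 to compound 2 (0.45 log units; beyond the scatter), which alters the group on the nitrogen and not the 4-methylphenyl ring.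

Compound 3, `NS(=O)(=O)Nc1ccc(NC(=O)Nc2cccc(-c3nc(-c4ccc(NC(=O)c5cccnc5)cc4Cl)no3)c2)cc1`, differs from compound 2 by sulfamoylamino in place of methyl on an aromatic carbon. Among the measured compounds shown here, no measured step touches this position, so the measured step gives no guide to its size or direction. Compound 3 is therefore expected to give 3500 nM, with a range from 1000 nM to 12000 nM. The expected step is no change at the digits printed from compound 2 to compound 3 (within the scatter), not beyond the scatter.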

Compound 3, half-maximal inhibitory concentration: 8900 nM
Estimate against measurement, compound 3: 2.5-fold (0.41 log units) below; low and high end bracket the measured number.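

In this assay, the aromatic carbon para to a large group, which the earlier step left untouched, proves sensitive to substitution: sulfamoylamino in place of methyl gives a 2.5-fold higher number from compound 2 to compound 3 (0.41 log units; beyond the scatter). The change weakens inhibition modestly, yet compound 3 still gives a number. Only compound 1 rests on a limit of the assay, not a number: the limit of > 10000 nM in this assay, at which 1 of the 3 values shown sits.

This single change at the position does not separate the effect of the added heavy atoms from that of the added hydrogen-bond donors and acceptors. On these data alone, how an amine, a carboxylic acid or a longer chain on this carbon would compare remains open.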